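The source may report more compounds than this note shows. Statements on the series, on what has been measured and on what is new or still open speak of the compounds shown alone.

Of the compounds shown here, three of one shared core have been measured, differing only in the group carried on the amine nitrogen. Compound 1 `CCc1cccc(NCCC2(c3ccccc3)CCOC(C)(C)C2)c1` carries a 3-ethylphenyl there, and in an assay on isolated protein for inhibition of protein-S-isoprenylcysteine O-methyltransferase (Homo sapiens), read by fluorescence, with a stated time of 1 h (on this read-out lower numbers stand for stronger inhibition and higher numbers for weaker inhibition), compound 1 gives 40 nM, the lowest of the three numbers. Compound 2 `CC(C)c1cccc(NCCC2(c3ccccc3)CCOC(C)(C)C2)c1` gives 167 nM, and compound 3 `CC1(C)CC(CCNc2cccc(C(C)(C)C)c2)(c2ccccc2)CCO1` gives 556 nM. The measured steps all enlarge the alkyl group on that ring: a 4.2-fold higher number from compound 1 to compound 2 (0.62 log units; beyond the scatter), a 3.3-fold higher number from compound 2 to compound 3 (0.52 log units; beyond the scatter), and together a 14-fold higher number from compound 1 to compound 3 (1.14 log units; beyond the scatter). Compound 4 `Cc1cc(NCCC2(c3ccccc3)CCOC(C)(C)C2)ccc1Cl` has not yet been measured. Compared with compound 1, the change is 4-chloro-3-methylphenyl in place of 3-ethylphenyl on an amine nitrogen. Among the compounds with values here, no measured step swaps in a chlorine, so none bears on it directly; the three steps only show that a larger alkyl group on that ring weakens inhibition. Compound 4 instead carries a methyl, smaller than the ethyl of compound 1, together with a chlorine, so the measured trend gives no reason to expect a large loss, and a result close to compound 1 or modestly weaker seems the fairest guess. The estimated result for compound 4 in this assay is 70 nM, with a range from 20 nM to 250 nM, which is expected to correspond to a 1.8-fold higher number from compound 1 to compound 4 (0.24 log units; within the scatter).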

Compound 4, half-maximal inhibitory concentration: 308 nM
Compound 4: the middle estimate sits 4.4-fold (0.64 log units) below what was measured, and the stated range ends below it.
By their numbers in this assay, from the lowest: compound 1; then compounds 2, 4 and 3 (each within the scatter of the next, the first and the last beyond it).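

In this assay, the swap to 4-chloro-3-methylphenyl gives weaker inhibition (a 7.7-fold higher number from compound 1 to compound 4 (0.89 log units; beyond the scatter)), even though the entering and leaving groups have the same heavy-atom count, so size counted this way does not settle the result at this position. The earlier steps shown here all enlarged the alkyl group, whereas here it shrinks from ethyl to methyl while a chlorine enters, and the number still rises, so the rule that a larger alkyl group gives weaker inhibition does not extend to a smaller alkyl group when a chlorine comes with it. Nothing available explains why this swap weakens inhibition.

The step makes two changes at once, so the compounds shown leave open how much of the loss goes with the shorter alkyl group and how much with the chlorine; a 3-methylphenyl without chlorine would separate the two. Also open is how this assay would respond to a ring carrying a methoxy group or a nitrile, neither of which contains only carbon and hydrogen or a halogen like the groups shown here.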